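Benzyl to phenyl on the amine of a quinone core

The source may report more compounds than this note shows. Statements on the series, on what has been measured and on what is new or still open speak of the compounds shown alone.

Measured so far:
Compound 1 `O=C1C=C(NCc2ccccc2)C(=O)c2c1nc1n2[C@H]2OC[C@@H](O)[C@H]2OC1`: > 8000 nM
Compound 2 `Cc1ccc(NC2=CC(=O)c3c(nc4n3[C@H]3OC[C@@H](O)[C@H]3OC4)C2=O)cc1C`: 4320 nM

Of the compounds shown here, two have been tested in a functional assay on HeLa cells (Homo sapiens) for inhibition, read by sulforhodamine B assay; on this read-out higher numbers stand for weaker inhibition and lower numbers for stronger inhibition. Compound 1 gives > 8000 nM, which is a limit of the assay and not a number; (the limit of > 8000 nM in this assay, at which 1 of the 2 values shown sits). Compound 2 gives 4320 nM in this assay. Since one of the two values is only a limit, the pair shows no more than that compound 2 reaches a measured number where compound 1 does not. For the measured compounds named here, no step between measured compounds that differ in a single place is available.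

Compound 3 `O=C1C=C(Nc2ccccc2)C(=O)c2c1nc1n2[C@H]2OC[C@@H](O)[C@H]2OC1` has not yet been measured. It differs from compound 1 in one place: phenyl in place of benzyl on an amine nitrogen. Compound 2 also carries an aromatic ring directly on the amine nitrogen and gives a measured number, whereas compound 1, with its benzyl group, stops at the limit. On that basis the step from compound 1 to compound 3 is expected to be an at least 1.3-fold lower number from compound 1 to compound 3 (0.12 log units; that floor lies within the scatter), towards stronger inhibition, though a starting limit leaves its size uncertain. Compound 3 is expected to give about 6000 nM in this assay, within a range from 2500 nM to 16000 nM.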

Compound 3, half-maximal inhibitory concentration: 5620 nM
The estimate for compound 3 lay 1.1-fold (0.03 log units) above the measured number, and the stated range covers the measured number.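

For the compounds shown here, with compound 3, the study gains its only comparison between compounds that differ in one place, phenyl in place of benzyl on an amine nitrogen, and this assay gives an at least 1.4-fold lower number from compound 1 to compound 3 (0.15 log units; that floor lies within the scatter). The result for compound 1 is a limit of the assay and not a number, so only a floor for this step can be read: the limit of > 8000 nM in this assay, at which 1 of the 3 values shown sits.
Swapping benzylamino for anilino on the shared core therefore moves the position from a limit to a measured number. Compound 3 gives 5620 nM. The printed floor alone does not establish a change larger than the usual scatter of repeated measurements.

As far as these compounds go, the true size of the step remains unknown, since a limit sets only one side of it and the real gap could be small or much larger. The compounds shown also leave open how this amine nitrogen would respond to a longer chain such as phenethyl, or to a phenyl ring carrying a carboxylic acid or a methoxy group.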